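Quinazoline sulfonamides: aryl variation on the sulfonyl group

A few compounds are considered here, and "the series" means these few. Any claim that something is new, unique, unknown or untested is made for them only; others in the source may bear on it.

Measured so far:
compound 1 `COc1cc2nc(N3CCN(S(=O)(=O)c4ccc(Cl)cc4)CC3)nc(N)c2cc1OC` — 23000 nM
compound 2 `COc1cc2nc(N3CCN(S(=O)(=O)c4ccc(C(C)(C)C)cc4)CC3)nc(N)c2cc1OC` — 4100 nM

Both measured compounds share one core and differ only in the aryl group on the sulfonyl sulfur. In a functional assay on PC-3 cells (Homo sapiens) for inhibition (a higher number here means a weaker inhibitor, a lower number a stronger inhibitor), compound 1 gives 23000 nM and compound 2 gives 4100 nM. Among the measured compounds shown here, the single measured step, a 5.6-fold lower number from compound 1 to compound 2 (0.75 log units; beyond the scatter), is the only guide available. Compound 2 thus holds the lowest number of the two, with compound 1 as its nearest neighbour.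

Compound 3 `COc1cc2nc(N3CCN(S(=O)(=O)c4cccc5ccccc45)CC3)nc(N)c2cc1OC` is not yet measured. Its change from compound 2 is naphthalen-1-yl in place of 4-(tert-butyl)phenyl on a sulfonyl sulfur. The measured step from compound 1 to compound 2 does bear on this, since it too alters the group on the sulfonyl sulfur, but it swapped one substituent on a single ring, whereas here a second fused ring enters and the substituent leaves; the two changes are not of the same kind, so the size of that step cannot be carried over directly. For the measured compounds named here, no measured pair shows what a second aromatic ring does.

The expectation is therefore a number near that of compound 2, with a modest shift in either direction possible, a 1.2-fold higher number from compound 2 to compound 3 (0.09 log units; within the scatter). Compound 3 is estimated at 5000 nM, within 1500 nM to 20000 nM.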

Compound 3, half-maximal inhibitory concentration: 14000 nM
Estimate against measurement, compound 3: 2.8-fold (0.45 log units) below; the measured number falls inside the stated range.
By their numbers in this assay, from the lowest: compound 2; then compounds 3 and 1 (each within the scatter of the next).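

In this assay the swap to naphthalen-1-yl on the sulfonyl sulfur gives a 3.4-fold higher number from compound 2 to compound 3 (0.53 log units; beyond the scatter) even though 4-(tert-butyl)phenyl and naphthalen-1-yl each hold 10 heavy atoms, all carbon, so an equal atom count at this position does not bring an equal number. Against 4-chlorophenyl, naphthalen-1-yl gives a 1.6-fold lower number from compound 1 to compound 3 (0.22 log units; within the scatter) and does not separate from it, which leaves 4-(tert-butyl)phenyl as the only one of the three aryl groups standing apart, with compound 2 the strongest inhibitor of the set. Nothing available here explains why these groups differ.

Still open, on these data alone, is whether the advantage of compound 2 belongs to the tert-butyl group itself or would also appear with a linear butyl chain, a methoxy group or an amine on the same single ring. Also open, as far as these compounds go, is whether naphthalen-2-yl would track naphthalen-1-yl, and whether a saturated ring such as cyclohexyl on the sulfonyl sulfur would hold the number of compound 2 without any aromatic ring there.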